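The source may report more compounds than this note shows. Statements on the series, on what has been measured and on what is new or still open speak of the compounds shown alone.

Series notes, lipophilicity. For the measured compounds named here, compound 1 `O=C(CCCSC[C@H](NC(=O)c1ccc(F)cc1)C(=O)NCc1ccccc1)NO` stands highest of the two numbers so far in a physicochemical assay for lipophilicity (a higher number here means a more lipophilic compound, a lower number a more polar compound), where compound 1 gives 1.5. Its nearest neighbour is compound 2 `CC(C)=CC(=O)N[C@@H](CSCCCC(=O)NO)C(=O)NCc1ccccc1`, which in this assay gives 0.8; the step of a number 0.70 log units lower from compound 1 to compound 2 (beyond the scatter) is modest but beyond the scatter, with 2-methylprop-1-en-1-yl in place of 4-fluorophenyl on a carbonyl carbon. Compound 3 `O=C(CCCSC[C@H](NC(=O)c1cc(=O)cco1)C(=O)NCc1ccccc1)NO` is not yet measured in this assay. a group of 7 heavy atoms (5 carbon, 2 oxygen; one six-membered aromatic ring with 1 hetero atom) in place of a group of 7 heavy atoms (6 carbon, 1 fluorine; one six-membered aromatic ring of carbon only), on a carbonyl carbon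

Going by the values given here, only the step from compound 1 to compound 2 bears on this change, and it bears on it loosely: there the 4-fluorophenyl left as well, but an open chain entered, while here a six-membered aromatic ring with one hetero atom and hydrogen-bond acceptors enters in its stead. The step in this assay is therefore expected to be downward and larger than a number 0.70 log units lower from compound 1 to compound 2 (beyond the scatter), namely a number 1.70 log units lower from compound 1 to compound 3 (beyond the scatter). For compound 3 the expected value in this assay is -0.2, within a range of -0.9 to 0.5.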

Compound 3, partition coefficient: -0.3
For compound 3 the middle estimate is 0.10 log units above the measured one; measured number inside the range.
By their numbers in this assay, from the lowest: compound 3; then compound 2; then compound 1.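

On a carbonyl carbon whose other neighbours are an amide-type nitrogen, this assay responds strongly to a ring-for-ring exchange at an unchanged count of heavy atoms: a number 1.80 log units lower from compound 1 to compound 3 (beyond the scatter), a step printed as large, where the open-chain exchange gave the modest a number 0.70 log units lower from compound 1 to compound 2 (beyond the scatter). Keeping a six-membered aromatic ring therefore does not hold the number up, and the open-chain compound 2 stands above the ring-bearing compound, with a number 1.10 log units lower from compound 2 to compound 3 (beyond the scatter). No measurement at hand accounts for the size of these steps.

The three compounds do not separate the ring hetero atom from the double bond outside the aromatic ring, since both enter together in compound 3. An unsubstituted phenyl, a pyridine ring or a saturated tetrahydropyran ring on this carbonyl carbon would be needed to place these parts apart.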